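Notes on one ring-group exchange in a small series

The source may hold more compounds than are shown below. What is called first, only, known or untested is meant among the compounds shown, and "the series" means these compounds.

Measured in a functional assay on CCRF-CEM cells (Homo sapiens) for antiproliferative activity, read by MTT assay, with a stated time of 72 h (on this read-out lower numbers stand for stronger inhibition and higher numbers for weaker inhibition), so far:
- compound 1 `O=C1O/C(=C\Cn2cnc3c(F)nc(F)c(Cl)c32)C(OCc2ccccc2)=C1OCc1ccccc1` gives "not determined" (no result reported) as its entry
- compound 2 `O=C1NC(O)(CCn2cnc3cc[nH]c3c2=O)C(OCc2ccccc2)=C1OCc1ccccc1` gives 87000 nM as its entry
- compound 3 `O=C1O/C(=C\Cn2cnc3cc[nH]c3c2=O)C(OCc2ccccc2)=C1OCc1ccccc1` gives 16000 nM as its entry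

Compound 3 holds the lower of the two numbers available, and compound 2 lies above it by a gap beyond the usual scatter. Compound 1 adds no number. Compound 4 `O=C1O/C(=C\Cn2cnc3cncc(Br)c32)C(OCc2ccccc2)=C1OCc1ccccc1` has yet to be measured and differs from compound 3 by a single exchange (a group of 10 heavy atoms (6 carbon, 3 nitrogen, 1 bromine; one five-membered aromatic ring with 2 hetero atoms, one six-membered aromatic ring with 1 hetero atom) in place of a group of 10 heavy atoms (6 carbon, 3 nitrogen, 1 oxygen; one five-membered aromatic ring with 1 hetero atom, one six-membered aromatic ring with 2 hetero atoms), on a saturated chain carbon bound to a double-bonded chain carbon) with the rest of the structure unchanged. Going by the values given here, no measured pair differs in one place alone. The only anchor for the expectation is compound 3 at 16000 nM as the closest measured structure, which leaves the size of the step poorly bounded. The estimated step is a 2.7-fold lower number from compound 3 to compound 4 (0.43 log units; beyond the scatter) in this assay and is expected to be a modest move to a lower number, though a result within the scatter would be no surprise. For compound 4 the estimated value is 6000 nM with an expected range of 1500 nM to 25000 nM as the working expectation.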

Compound 4, half-maximal inhibitory concentration: 5700 nM
Compound 4: the middle estimate sits 1.1-fold (0.02 log units) above what was measured; measured number inside the range.
By their numbers in this assay, from the lowest: compound 4; then compound 3; then compound 2.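

In this assay, going by these compounds alone, the only single-place comparison is a 2.8-fold lower number from compound 3 to compound 4 (0.45 log units; beyond the scatter), so the ring group on a saturated chain carbon bound to a double-bonded chain carbon can be exchanged without losing activity, and the number moves beyond the scatter. The exchange alters several features at once: oxygen gives way to bromine, the hetero atoms are distributed differently over the two rings, and 1 hydrogen-bond donor gives way to 0 hydrogen-bond donors, so the step cannot be assigned to any one of them. No measurement on hand bears on why the number moved.

Going by these compounds, whether the bromine itself carries the step remains open. So does whether an amine or a carboxylic acid in its place would keep, enlarge or reverse it.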